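Pentyl for Methoxyphenyl on the Amide Nitrogen

A few compounds are considered here, and "the series" means these few. Any claim that something is new, unique, unknown or untested is made for them only; others in the source may bear on it.

compound 1, `c1ccc(Cn2cnc3c(-c4ccco4)nccc32)cc1`: > 25000 nM
compound 2, `COc1ccc(NC(=O)COc2cc(C)nc3ccc(OC)cc23)cc1`: > 142000 nM
compound 3, `COc1ccc(NC(=O)COc2cc(C)nc3ccc(OC)cc23)c(OC)c1`: > 131000 nM

In an ADME assay on HepG2 cells (Homo sapiens) for cytotoxicity, read by trypan blue exclusion, with a stated time of 48 h, in the presence of a further agent that is not named here (a higher number here means that more compound is tolerated, a lower number that less compound is tolerated), compound 2 gives only a limit, > 142000 nM. Every other value shown is a limit as well: the limit of > 131000 nM in this assay, at which 1 of the 3 values shown sits, the limit of > 142000 nM in this assay, at which 1 of the 3 values shown sits, and (the limit of > 25000 nM in this assay, at which 1 of the 3 values shown sits). Compound 2 therefore cannot be ranked against compound 1 or compound 3; all three tolerated the highest concentration that was tested for them. Going by the values given here, the one step between measured compounds, a step that the two limits leave unreadable from compound 2 to compound 3, cannot be read, since both ends are limits.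

Compound 4, `CCCCCNC(=O)COc1cc(C)nc2ccc(OC)cc12`, differs from compound 2 in one place: pentyl in place of 4-methoxyphenyl on an amide-type nitrogen. Among the compounds with values here, no measured step touches the substituent on the amide nitrogen, so nothing here speaks for or against a change beyond the scatter. Within the data shown here, the three limits together, however, show no compound of this set reaching a measurable half-maximal cytotoxic concentration, and compound 4 is expected to behave in the same way. In this assay compound 4 is therefore estimated at 130000 nM, with a range from 40000 nM to 300000 nM. The step from compound 2 to compound 4 is expected to be an at least 1.0-fold lower number from compound 2 to compound 4 (0.03 log units; that floor lies within the scatter), most likely again reported only as a limit.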

Compound 4, half-maximal cytotoxic concentration: > 158000 nM
Compound 4 gave a limit, no number; the forecaster's own chance of this, stated with the estimate: 75%; middle value at least 1.2-fold (0.08 log units) from the limit.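

In this assay compound 4 gives > 158000 nM, which is a limit and not a number. Compound 2 also has only a limit, so the step between the two cannot be read. The compounds shown leave open whether pentyl and 4-methoxyphenyl on the amide-type nitrogen differ in tolerated concentration at all; all four values shown are limits.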